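Methyl for Cycloheptyl on a Ring Nitrogen: Cathepsin S Binding

A few compounds are considered here, and "the series" means these few. Any claim that something is new, unique, unknown or untested is made for them only; others in the source may bear on it.

Compound 1 `N#CC1(NC(=O)[C@@H](CC(=O)N2CCOCC2)CC2CCCCC2)CC1`: 12 nM
Compound 2 `N#C[C@@]1(NC(=O)[C@@H](CC(=O)N2CCOCC2)CC2CCCCC2)CCN(C2CCCCCC2)C1`: 11 nM

Of the compounds shown here, two have been measured in an assay on isolated protein for inhibition of cathepsin S (Homo sapiens); a lower number here means tighter binding, a higher number weaker binding. Compound 1 gives 12 nM in this assay, and compound 2 gives 11 nM. The two numbers lie within the scatter of each other, so neither compound can be set apart from the other on this evidence; compound 2 simply shares the level that compound 1 shows. Compound 3 `CN1CC[C@@](C#N)(NC(=O)[C@@H](CC(=O)N2CCOCC2)CC2CCCCC2)C1` has not yet been measured in this assay. It differs from compound 2 in one place: methyl in place of cycloheptyl on an amine nitrogen in a ring. Going by the values given here, no measured step shows what such a change does, so the account is open. Since compound 1, which carries no such ring at all, gives 12 nM and compound 2 gives 11 nM, the group on the ring nitrogen has not shown itself to matter; the step from compound 2 to compound 3 is expected to be small, a 1.4-fold higher number from compound 2 to compound 3 (0.13 log units; within the scatter), likely within the scatter. Compound 3 is estimated at 15 nM, in the range 5 nM to 50 nM.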

Compound 3, dissociation constant: 161 nM
Beside the measured number, compound 3's estimate is 11-fold (1.03 log units) below it; the whole stated range lies below it.
By their numbers in this assay, from the lowest: compounds 2 and 1 (each within the scatter of the next); then compound 3.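

In this assay, going by these compounds alone, the group on the ring nitrogen proves to matter: methyl in place of cycloheptyl gives a 15-fold higher number from compound 2 to compound 3 (1.17 log units; beyond the scatter), so the close agreement between the earlier compounds did not mean that this position was indifferent. The five-membered ring with a methyl on its nitrogen also does not hold the level of the 1-cyanocyclopropyl compound, as 3-cyano-1-methylpyrrolidin-3-yl in place of 1-cyanocyclopropyl gives a 13-fold higher number from compound 1 to compound 3 (1.13 log units; beyond the scatter). Nothing available explains why the number rises at this position.

With only cycloheptyl and methyl shown on this nitrogen, it remains open where between them the number changes, and whether an ethyl, a cyclopentyl or a benzyl group would recover the level of compound 2. From the compounds shown here alone, how a ring nitrogen carrying only hydrogen, or an acetyl group, would behave also remains open.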